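Compound 1 to compound 4: one methoxy group leaves

The source may hold more compounds than are shown below. What is called first, only, known or untested is meant among the compounds shown, and "the series" means these compounds.

In a functional assay on PC-3 cells (Homo sapiens) for cytotoxicity, read by MTT assay, with a stated time of 72 h (a higher number here means a weaker inhibitor, a lower number a stronger inhibitor), compound 1 `COc1cc(/C=C/C=O)cc(OC)c1OC/C=C(\C)CCC=C(C)C` gives 39000 nM. Compound 3 `COc1cc(/C=C/C=O)cc(OC)c1OCC=C(C)C` gives 28000 nM, which lies within the scatter of the value for compound 1, so these two stand level. Compound 2 `COc1cc(/C=C/C(=O)O)ccc1OCC=C(C)C` gives only a limit of the assay, > 100000 nM, and not a number. Compound 1 therefore has one numerical neighbour, and that neighbour is close.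

Compound 4 `COc1cc(/C=C/C=O)ccc1OC/C=C(\C)CCC=C(C)C` has not yet been measured. It comes from compound 1 by a single change, hydrogen in place of methoxy on an aromatic carbon. The long chain and the 2-formylethenyl group stay as they are.

Among the compounds with values here, no measured step isolates the loss of this methoxy group. The nearest guide is a change made elsewhere in the molecule, on the chain, and it leaves the methoxy group in place: a 1.4-fold lower number from compound 1 to compound 3 (0.14 log units; within the scatter). That is weak evidence, but it gives no reason to predict a large move in this assay. The estimated step is a 1.2-fold higher number from compound 1 to compound 4 (0.06 log units; within the scatter), and no clear direction is expected beyond the scatter. For compound 4 the expected value is 45000 nM, with an estimated range from 20000 nM to 100000 nM.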

Compound 4, half-maximal inhibitory concentration: 24000 nM
For compound 4 the middle estimate is 1.9-fold (0.27 log units) above the measured one; low and high end bracket the measured number.
By their numbers in this assay, from the lowest: compounds 4, 3 and 1 (each within the scatter of the next). At a limit, above all of these: compound 2.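

In this assay, this is the first single change shown on the aromatic ring and not on the chain, and it gives a 1.6-fold lower number from compound 1 to compound 4 (0.21 log units; within the scatter). Hydrogen can therefore stand in place of methoxy on this aromatic carbon, ortho to a large group, with no move beyond the scatter, at least while the long chain and the 2-formylethenyl group stay as they are. The step on the chain, a 1.4-fold lower number from compound 1 to compound 3 (0.14 log units; within the scatter), is also within the scatter, so neither of the two single changes that can be read here separates its pair of compounds in this cell assay.

As far as these compounds go, whether another group on this aromatic carbon, such as an amine, a hydroxyl group or a longer alkoxy chain, would give a number beyond the scatter remains open, as does whether losing this methoxy group would give the same result with the chain of compound 3 in place of the long chain. One value in this set is only a limit of the assay and offers no number for comparison: the limit of > 100000 nM in this assay, at which 1 of the 4 values shown sits.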